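A few compounds are considered here, and "the series" means these few. Any claim that something is new, unique, unknown or untested is made for them only; others in the source may bear on it.

Of the compounds shown here, three of one shared core have so far been tested. Compound 1 `N#CC1=C(N)OC(c2c[nH]c3ccccc23)=C(C#N)C1c1ccccc1F` gave "not active" (no number reported) in a functional assay, tested at 50 ug/mL (a higher number here means a stronger effect of the compound at the concentration tested, a lower number a weaker effect), and compound 2 `N#CC1=C(N)OC(c2c[nH]c3ccccc23)=C(C#N)C1c1ccc2ccccc2c1` likewise gave "not active" (no number reported) in this assay, so for neither of these is there a number to compare. Among the measured compounds shown here, compound 3 `Cc1ccc(C2C(C#N)=C(N)OC(c3c[nH]c4ccccc34)=C2C#N)cc1` is the only one with a measured number: in this assay compound 3 gives 5.2%, a weak effect at the concentration tested. Compound 3 therefore stands alone as the single point of reference, with nothing above or below it to set it against.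

The next compound, compound 4 `N#CC1=C(N)OC(c2c[nH]c3ccccc23)=C(C#N)C1c1ccccc1`, is still to be measured in this assay. It differs from compound 3 in one place only: hydrogen in place of methyl on an aromatic carbon. For the measured compounds named here, since no pair of measured compounds shares a single change of this kind, there is no measured step to lean on. Given that compound 3 already sits at a low level of activity, the expected movement is none beyond the usual scatter, and the step from compound 3 to compound 4 is estimated at a number 1.2 percentage points lower from compound 3 to compound 4 (within the scatter). Compound 4 is accordingly expected to show about 4% in this assay, within a range from 0% to 12%.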

Compound 4, a percentage reported as activity, at one concentration (the size of the read-out at that concentration, not a potency): 14.4%
Compound 4: middle estimate off by 10.4 percentage points, on the low side, outside the stated range (above it).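

Replacing the methyl with hydrogen on the aromatic ring, at the carbon para to a large group, gives a number 9.2 percentage points higher from compound 3 to compound 4 (within the scatter) in this assay. Among the compounds shown here, this is the first measured single change, and it shows that 4-methylphenyl and phenyl cannot be told apart at this place, so the methyl is not needed for compound 4 to give a measurable read-out. Nothing available here accounts for the size of this step, and with the step inside the scatter there is no effect of the methyl to explain.

From the compounds shown here alone, one pair of compounds says little about this place as a whole, so what a chlorine atom, a methoxy group or a carboxylic acid would give there, and whether any of them would stand clear of the scatter, remains open. Also open, going by these compounds, is how this assay would respond to a change elsewhere on the shared core, such as an amide in place of a nitrile or a methyl group on the indole nitrogen.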